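Urea-linked benzimidazole series: changing the benzyloxy substituent

A few compounds are considered here, and "the series" means these few. Any claim that something is new, unique, unknown or untested is made for them only; others in the source may bear on it.

Measured compounds:
compound 1, `Cc1ccc(NC(=S)NC(=O)c2ccc(OCc3ccccc3)cc2)cc1-c1nc2ccccc2[nH]1`, 67100 nM
compound 2, `O=C(NC(=S)Nc1ccc(Cl)c(-c2nc3ccccc3[nH]2)c1)c1ccc(OCc2ccc(Cl)cc2Cl)cc1`, 50200 nM
compound 3, `Cc1ccc(NC(=O)NC(=O)c2ccc(OCc3ccccc3F)cc2)cc1-c1nc2ccccc2[nH]1`, 4110 nM

In a functional assay on SW-620 cells (Homo sapiens) for inhibition, read by MTT assay, with a stated time of 48 h (on this read-out lower numbers stand for stronger inhibition and higher numbers for weaker inhibition), compound 3 gives 4110 nM, the lowest of the three numbers. Its nearest neighbour is compound 2 with 50200 nM, a gap beyond the scatter, and the furthest is compound 1 with 67100 nM, also beyond the scatter. Compound 3 therefore stands apart from the two thiourea-linked analogues on this read-out.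

Compound 4, `Cc1ccc(NC(=O)NC(=O)c2ccc(OCc3ccc(Cl)c(Cl)c3)cc2)cc1-c1nc2ccccc2[nH]1`, has not yet been measured. It differs from compound 3 in one place: 3,4-dichlorophenyl in place of 2-fluorophenyl on a saturated chain carbon bound to an oxygen on an aromatic ring. Among the compounds with values here, no measured pair in this set shows the effect of such a change alone, so there is no directly comparable step to lean on. The expectation is that the step from compound 3 to compound 4 in this assay will be small and will not clearly leave the scatter, a 1.0-fold lower number from compound 3 to compound 4 (0.01 log units; within the scatter), with a direction that cannot be called from the numbers at hand. Compound 4 is accordingly estimated at 4000 nM, in a range from 1500 nM to 12000 nM.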

Compound 4, half-maximal inhibitory concentration: 6100 nM
Beside the measured number, compound 4's estimate is 1.5-fold (0.18 log units) below it; measured number inside the range.
By their numbers in this assay, from the lowest: compounds 3 and 4 (each within the scatter of the next); then compounds 2 and 1 (each within the scatter of the next).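

In this assay, the step of a 1.5-fold higher number from compound 3 to compound 4 (0.17 log units; within the scatter), with 3,4-dichlorophenyl in place of 2-fluorophenyl on a saturated chain carbon bound to an oxygen on an aromatic ring, lies within the scatter. This is the first pair among the compounds shown that differs in this one place alone, and on the shared urea-linked core the two groups cannot be told apart on this read-out. Nothing at hand gives a reason for this result.

No pair shown differs only in the urea or thiourea link, so the separate effect of that link remains open. Also open, on these data alone, is whether an amine or a carboxylic acid on this phenyl ring, or a longer chain in place of the benzyl group, would give a step beyond the scatter.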